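Replacing the 2-hydroxyphenyl group of compound 3

The source may hold more compounds than are shown below. What is called first, only, known or untested is meant among the compounds shown, and "the series" means these compounds.

Measured in an ADME assay (liver) for metabolic stability, with Liver microsome (Rattus norvegicus) as the target, using microsomes and NADPH, with a stated time of 30 min, tested at 1 uM (on this read-out lower numbers stand for slow clearance and higher numbers for fast clearance), on one shared core:
Compound 1 `CC(C)(C)n1cc(-c2cc(C(O)(C(F)(F)F)C(F)(F)F)cnc2N2CCN(S(=O)(=O)c3ccc(N)nc3)CC2)cn1` gives 459 mL.min-1.g-1
Compound 2 `Cc1csc(-c2cc(C(O)(C(F)(F)F)C(F)(F)F)cnc2N2CCN(S(=O)(=O)c3ccc(N)nc3)CC2)c1` gives 399 mL.min-1.g-1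
Compound 3 `Nc1ccc(S(=O)(=O)N2CCN(c3ncc(C(O)(C(F)(F)F)C(F)(F)F)cc3-c3ccccc3O)CC2)cn1` gives 125 mL.min-1.g-1

Compound 3 has the lowest number of the three in this assay and so shows the slowest clearance. The unmeasured compound 4 `CS(=O)(=O)c1ccc(-c2cc(C(O)(C(F)(F)F)C(F)(F)F)cnc2N2CCN(S(=O)(=O)c3ccc(N)nc3)CC2)cc1` keeps the shared core and changes one group: 4-(methylsulfonyl)phenyl in place of 2-hydroxyphenyl on an aromatic carbon at the same place where the three measured compounds differ.

Their steps are therefore the best guide. Introducing 2-hydroxyphenyl gave a 3.7-fold lower number from compound 1 to compound 3 (0.56 log units; beyond the scatter) and a 3.2-fold lower number from compound 2 to compound 3 (0.50 log units; beyond the scatter) and both steps are modest, while only a 1.2-fold lower number from compound 1 to compound 2 (0.06 log units; within the scatter) stays within the scatter. Going by the values given here, no measured compound carries 4-(methylsulfonyl)phenyl, so the direction is uncertain. Like 2-hydroxyphenyl, the new group holds one six-membered aromatic ring of carbon only, so compound 3 at 125 mL.min-1.g-1 is the natural starting point. A small rise is expected, and the estimated step is a 1.4-fold higher number from compound 3 to compound 4 (0.13 log units; within the scatter) with no larger move than those modest steps as the likely outcome. Compound 4 is estimated at 170 mL.min-1.g-1 with an expected range from 70 mL.min-1.g-1 to 420 mL.min-1.g-1 on this read-out.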

Compound 4, intrinsic clearance in microsomes: 103 mL.min-1.g-1
Estimate against measurement, compound 4: 1.7-fold (0.22 log units) above; low and high end bracket the measured number.
By their numbers in this assay, from the lowest: compounds 4 and 3 (each within the scatter of the next); then compounds 2 and 1 (each within the scatter of the next).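

In this assay, putting 4-(methylsulfonyl)phenyl in place of 2-hydroxyphenyl on this aromatic carbon gives a 1.2-fold lower number from compound 3 to compound 4 (0.08 log units; within the scatter) and so leaves the two compounds indistinguishable, which shows that a low number here does not need the hydrogen-bond donor of 2-hydroxyphenyl and survives a larger group with a quite different substituent. The same group also gives a 3.9-fold lower number from compound 2 to compound 4 (0.59 log units; beyond the scatter) and a 4.5-fold lower number from compound 1 to compound 4 (0.65 log units; beyond the scatter) in the same read-out, so among these four compounds both substituted phenyl groups give lower numbers than 4-methylthiophen-2-yl and 1-(tert-butyl)-1H-pyrazol-4-yl, and no compound shown goes against that pattern. Nothing available here accounts for this difference between the groups.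

On these data alone, it remains open whether the phenyl ring alone is enough, which a plain phenyl group or a phenyl carrying an amine or a carboxylic acid would help to settle. The two substituents also differ in both identity and place on the ring, so a 4-hydroxyphenyl or a 2-(methylsulfonyl)phenyl group would be needed to separate those two changes.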